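Removing one methyl group from compound 1

The source may report more compounds than this note shows. Statements on the series, on what has been measured and on what is new or still open speak of the compounds shown alone.

Compound 1 `COc1cccc(/C=C/C(=O)c2c(OC)cc(OC)cc2OC)c1` was tested in a functional assay on MDA-MB-231 cells (Homo sapiens), read by fluorescence and BrdU incorporation, with a stated time of 48 h, tested at 10 uM (a lower number here means a stronger effect, a higher number a weaker effect of the compound at the concentration tested), and gives 43%. Compound 2 `COc1cc(OC)c(C(=O)/C=C/c2ccc(Br)cc2)c(OC)c1` gives 42% in this assay. Among the measured compounds shown here, of these two numbers, compound 1 holds the higher one, but the single measured step, a number 1 percentage points lower from compound 1 to compound 2 (within the scatter), lies within the scatter, so the two compounds cannot be told apart on this read-out. That step swaps one ring on the chain for another and leaves the shared core untouched.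

Compound 3 `COc1cccc(/C=C/C(=O)c2c(O)cc(OC)cc2OC)c1` is not yet measured. It differs from compound 1 by hydrogen in place of methyl on an oxygen on an aromatic ring. For the measured compounds named here, no measured step touches this part of the molecule; the one step that is known, a number 1 percentage points lower from compound 1 to compound 2 (within the scatter), alters a different ring and changed nothing beyond the scatter. Going by the values given here, with no step pointing either way, the change to compound 3 is expected to move the number little, if at all, in this assay. Compound 3 is therefore estimated to give 43%, within 25% to 62%. That estimate means a step of no change at the digits printed from compound 1 to compound 3 (within the scatter), which is expected to stay within the scatter.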

Compound 3, a percentage reported as activity, at one concentration (the size of the read-out at that concentration, not a potency): 54%
Compound 3: middle estimate off by 11 percentage points, on the low side, within the range that was stated.
By their numbers in this assay, from the lowest: compounds 2 and 1 (each within the scatter of the next); then compound 3.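

In this assay, hydrogen in place of methyl on an oxygen on an aromatic ring gives a number 11 percentage points higher from compound 1 to compound 3 (beyond the scatter) and so, on this read-out, a weaker effect at the concentration tested. This is the first change among these compounds to move the number beyond the scatter, so the shared core is not indifferent to change: losing a single methyl group, methoxy to hydroxy, is enough to be seen, even though the step is modest. Nothing available explains the loss, and the size of the step alone cannot give its cause.

What the compounds shown leave open is whether the methyl group itself matters or whether other groups on this oxygen would serve equally well, such as a longer chain like ethyl, or whether an amine in place of the hydroxy would give a different number. Also open, as far as these compounds go, is whether the other methoxy groups on this ring would respond in the same way, and, with one concentration only, how the step would translate into a difference in potency.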